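Replacing the side group of compound 3 with an oxanyl amine

The compounds below may be only part of what the source reports. "The series", "measured", "known", "first", "only" and "open" are said of these compounds alone.

Three compounds on the shared core have numbers in an ADME assay on microsomes from liver (Mus musculus) for metabolic stability, using NADPH, with a stated time of 10 min; a higher number here means that more of the compound is left, a lower number that less of the compound is left. Compound 1 `NC/C=C/CN(C[C@H]1Cc2ncccc2CN1)[C@H]1CCCc2cccnc21` gives 37%, compound 2 `NC(=O)NCCCCN(C[C@H]1Cc2ncccc2CN1)[C@H]1CCCc2cccnc21` gives 32%, and compound 3 `NC(=O)NC/C=C/CN(C[C@H]1Cc2ncccc2CN1)[C@H]1CCCc2cccnc21` gives 19%. Compound 3 is therefore the lowest of the three, with both gaps beyond the scatter.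

Compound 4 `c1cnc2c(c1)CN[C@@H](CN(CCCCNC1CCOCC1)[C@H]1CCCc3cccnc31)C2` differs from compound 3 by a group of 10 heavy atoms (8 carbon, 1 nitrogen, 1 oxygen; one six-membered non-aromatic ring with 1 hetero atom) in place of a group of 7 heavy atoms (4 carbon, 2 nitrogen, 1 oxygen; no ring), on a saturated chain carbon bound to an amine nitrogen. The entering 3-((oxan-4-yl)amino)propyl sits on a saturated chain carbon bound to an amine nitrogen.

Going by the values given here, three measured steps bear on this change. a number 18 percentage points lower from compound 1 to compound 3 (beyond the scatter) came with carbamoyl in place of hydrogen on an amine nitrogen, and compound 4 has no carbamoyl. a number 13 percentage points lower from compound 2 to compound 3 (beyond the scatter) came with a change of the chain, and compound 4 shares the propyl ending of its group name with 3-ureidopropyl in compound 2. a number 5 percentage points lower from compound 1 to compound 2 (within the scatter) shows that the two higher compounds stand within the scatter of each other. Both larger steps run down towards compound 3, so a modest move back up is expected. Among the compounds with values here, no measured compound carries the oxane ring, which leaves the range wide.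

The expected change is a number 11 percentage points higher from compound 3 to compound 4 (beyond the scatter). For compound 4 the estimate is 30%, with an expected range of 14% to 50%.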

Compound 4, percent of the compound remaining: 35%
Beside the measured number, compound 4's estimate is 5 percentage points below it; the measured number falls inside the stated range.
By their numbers in this assay, from the lowest: compound 3; then compounds 2, 4 and 1 (each within the scatter of the next).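

In this assay the entering 3-((oxan-4-yl)amino)propyl, on a saturated chain carbon bound to an amine nitrogen, gives a number 16 percentage points higher from compound 3 to compound 4 (beyond the scatter) and so shows that this place takes a group with one six-membered non-aromatic ring with 1 hetero atom and no carbamoyl without a further loss in the number. Oxan-4-yl in place of carbamoyl on an amine nitrogen gives a number 3 percentage points higher from compound 2 to compound 4 (within the scatter) while 3-((oxan-4-yl)amino)propyl in place of 3-aminoprop-1-en-1-yl gives a number 2 percentage points lower from compound 1 to compound 4 (within the scatter) in the same assay. Compounds 1, 2 and 4 therefore form one level within the scatter despite their different side groups, and compound 3 alone stands apart from all three, lowest in this small set.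

Going by these compounds, it remains open whether the oxan-4-yl group itself matters for this level or whether another group on the same amine nitrogen, such as piperidin-4-yl or cyclohexyl, would give a similar number in this assay on the shared core. No supporting data are available to explain any of these steps.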